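Swapping Chloro for Trifluoromethyl on the Urea Aryl Ring

This account rests on a few compounds, and the source may have more. Where it says the series, first, only, none or still open, it means among the compounds named here.

Going by the values given here, compound 1 `CC(C)CN(CC(C)C)c1ccc(/C(=N/O)Nc2ccc(F)c(Br)c2)cc1NC(=O)Nc1ccc(Cl)cc1` is one of three compounds measured in an assay on HeLa cells for inhibition of Indoleamine 2,3-dioxygenase 1 (Homo sapiens) (a higher number here means a weaker inhibitor, a lower number a stronger inhibitor), and compound 1 gives 440 nM. Compound 2 `Cc1ccc(NC(=O)Nc2cc(/C(=N/O)Nc3ccc(C)cc3)ccc2N(CC(C)C)CC(C)C)cc1` gives 1340 nM, and compound 3 `CC(C)CN(CC(C)C)c1ccc(/C(=N/O)Nc2ccc(F)c(Br)c2)cc1NC(=O)Nc1cncnc1` gives 860 nM. On these numbers compound 1 stands lowest; its gap to compound 3 lies within the scatter, while its gap to compound 2 lies beyond it. Among the compounds with values here, the only step between compounds that differ in one place is a 2.0-fold higher number from compound 1 to compound 3 (0.29 log units; within the scatter), which exchanges the whole aryl group on the urea nitrogen without moving the number beyond the scatter.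

Compound 4 `CC(C)CN(CC(C)C)c1ccc(/C(=N/O)Nc2ccc(F)c(Br)c2)cc1NC(=O)Nc1ccc(C(F)(F)F)cc1` keeps everything else of compound 1 and differs only in this way: trifluoromethyl in place of chloro on an aromatic carbon. Within the data shown here, no measured step changes this substituent alone; the nearest comparison, the single step in this assay, shows that exchanges at this end of the urea left the number almost where it was. The step is therefore expected to be small, a 1.1-fold higher number from compound 1 to compound 4 (0.06 log units; within the scatter), in no direction beyond the scatter. Compound 4 is thus estimated at 500 nM, with a range from 200 nM to 1300 nM.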

Compound 4, half-maximal inhibitory concentration: 2090 nM
For compound 4 the middle estimate is 4.2-fold (0.62 log units) below the measured one, outside the stated range (above it).
By their numbers in this assay, from the lowest: compounds 1, 3, 2 and 4 (each within the scatter of the next, the first and the last beyond it).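

Exchanging one substituent at this end of the urea matters more in this assay than the earlier comparison suggested: trifluoromethyl in place of chloro gives a 4.8-fold higher number from compound 1 to compound 4 (0.68 log units; beyond the scatter), while the larger exchange of 4-chlorophenyl for pyrimidin-5-yl had stayed within the scatter. The 4-(trifluoromethyl)phenyl group also separates from pyrimidin-5-yl, with a 2.4-fold higher number from compound 3 to compound 4 (0.39 log units; beyond the scatter), so of the three groups compared on this urea nitrogen it gives the highest number. No measurement shown here explains why this substituent raises the number.

As far as these compounds go, it remains open whether a methoxy group or a carboxylic acid at this place would stay close to compound 1 or move towards compound 4. Compound 2 differs from compound 1 in more than one place, so it cannot settle how other substituents behave here.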